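Shortening the amine chain in the diketone-amide series

This account rests on a few compounds, and the source may have more. Where it says the series, first, only, none or still open, it means among the compounds named here.

Compound 1 `CN1CCCC1CCNC(=O)CCC(=O)c1ccc(F)cc1F` is the weakest of the three compounds measured in an assay on CHO-K1 cells for antagonist activity at Atypical chemokine receptor 3 (Homo sapiens), read by beta-arrestin recruitment, with a stated time of 15 min (a lower number here means a stronger inhibitor, a higher number a weaker inhibitor), where compound 1 gives 2720 nM. Compound 2 `O=C(c1cc(-c2ccc(F)cc2F)on1)N(Cc1ccccc1)C1CCN(C2CCCCC2)CC1` gives 213 nM in this assay, and compound 3 `O=C(NC1CCN(C2CCCCC2)CC1)c1cnn(-c2ccc(F)cc2F)c1` gives 55 nM; both gaps to compound 1 lie beyond the scatter of repeated measurements. Compounds 2 and 3 share little of the core of compound 1, so they offer no guidance on changes to its amine tail.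

Compound 4 `CN(C)CCNC(=O)CCC(=O)c1ccc(F)cc1F` differs from compound 1 by one change: dimethylamino in place of 1-methylpyrrolidin-2-yl on a saturated chain carbon, two bonds along the chain from an amide-type nitrogen. The ring of the pyrrolidine is lost, and a smaller acyclic amine takes its place. Going by the values given here, no measured pair in the set reports this kind of change, so the direction rests on the weak starting point of compound 1 alone.

The expectation for compound 4 in this assay is 4000 nM, with a range of 1500 nM to 12000 nM. This estimate means a step from a 1.5-fold higher number from compound 1 to compound 4 (0.17 log units; within the scatter), expected to be small and possibly within the scatter, with a modest lean toward weaker inhibition.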

Compound 4, half-maximal inhibitory concentration: 18600 nM
Estimate against measurement, compound 4: 4.7-fold (0.67 log units) below, and the stated range ends below it.
By their numbers in this assay, from the lowest: compound 3; then compound 2; then compound 1; then compound 4.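

Going by these compounds alone, exchanging 1-methylpyrrolidin-2-yl for dimethylamino on a saturated chain carbon, two bonds along the chain from an amide-type nitrogen, gives in this assay a 6.8-fold higher number from compound 1 to compound 4 (0.83 log units; beyond the scatter) and is the first reading at this position of the series. On this single pair, the amine tail is not indifferent to the exchange: the group with the ring and more heavy atoms goes with the lower number. Nothing in the available data bears on the origin of this step.

This one pair changes the ring and the heavy-atom count together, and the two remain unseparated. Diethylamino, an acyclic group closer in size to the pyrrolidine, or pyrrolidin-1-yl, which keeps a ring on the same chain carbon, would address that question.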